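Swapping a Benzimidazole for Cyclohexyl in Cell Growth Inhibitors

The source may report more compounds than this note shows. Statements on the series, on what has been measured and on what is new or still open speak of the compounds shown alone.

Compound 1 `Cc1cc(Nc2cc(-c3ccccc3)[nH]n2)n2nc(SCc3cccc(Br)c3)nc2n1`: 4820 nM
Compound 2 `Cc1cc(Nc2cc(-c3ccccc3)[nH]n2)n2nc(SCc3nc4ccccc4[nH]3)nc2n1`: 1790 nM
Compound 3 `Cc1ccc(Cn2ccc(Nc3cc(C)nc4nc(SCc5ccc(Br)cc5)nn34)n2)cc1`: 7420 nM

Of the compounds shown here, three built on a shared core have been tested in a functional assay on MGC-803 cells (Homo sapiens) for inhibition, read by MTT assay, with a stated time of 72 h; a lower number here means a stronger inhibitor, a higher number a weaker inhibitor. Compound 1 gives 4820 nM, compound 2 gives 1790 nM and compound 3 gives 7420 nM. Compound 2 has the lowest number of the three and is therefore the strongest inhibitor among them; compound 1 comes nearest and compound 3 lies furthest away.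

Going by the values given here, only one single-change step exists among the measured compounds: a 2.7-fold lower number from compound 1 to compound 2 (0.43 log units; beyond the scatter). It shows that the group on the saturated chain carbon bound to a sulfur shifts the number, with the 1H-benzimidazol-2-yl giving the lower value.

Compound 4 `Cc1cc(Nc2cc(-c3ccccc3)[nH]n2)n2nc(SCC3CCCCC3)nc2n1` continues from compound 2 with this change: cyclohexyl in place of 1H-benzimidazol-2-yl on a saturated chain carbon bound to a sulfur. Among the compounds with values here, no measured step covers this exact swap. Within the data shown here, the expectation is a higher number for compound 4, because a 2.7-fold lower number from compound 1 to compound 2 (0.43 log units; beyond the scatter) showed the one other group at this position giving a weaker result than the 1H-benzimidazol-2-yl, and the step is expected to be modest. Compound 4 is estimated at 5000 nM, with a range from 2000 nM to 15000 nM. This estimate amounts to an expected step of a 2.8-fold higher number from compound 2 to compound 4 (0.45 log units; beyond the scatter).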

Compound 4, half-maximal inhibitory concentration: 12600 nM
For compound 4 the middle estimate is 2.5-fold (0.40 log units) below the measured one; measured number inside the range.
By their numbers in this assay, from the lowest: compound 2; then compounds 1, 3 and 4 (each within the scatter of the next, the first and the last beyond it).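

With a third group on this saturated chain carbon bound to a sulfur, the comparison in this assay extends beyond a single pair: the change to cyclohexyl gives a 7.0-fold higher number from compound 2 to compound 4 (0.85 log units; beyond the scatter). The same group also compares unfavourably with 3-bromophenyl, with a 2.6-fold higher number from compound 1 to compound 4 (0.42 log units; beyond the scatter), so among these three groups the two aromatic ones give lower numbers than the non-aromatic ring, and 1H-benzimidazol-2-yl gives the lowest. No measurement shown here explains these differences.

The compounds shown leave open whether the lower number of compound 2 depends on the ring nitrogens and their hydrogen-bond donor and acceptor or on the two-ring aromatic shape. A 1H-imidazol-2-yl, a plain phenyl or a naphthyl group on this carbon would help separate these possibilities.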